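Acylating the ring amine of compound 2

The compounds below may be only part of what the source reports. "The series", "measured", "known", "first", "only" and "open" are said of these compounds alone.

Of the compounds shown here, three sharing one core have been measured in a functional assay on HCT-116 cells (Homo sapiens) for antiproliferative activity; a higher number here means a weaker inhibitor, a lower number a stronger inhibitor. Compound 1 (`Cc1c2c(n3c1CCCNC[C@H](C)Nc1cc-3ccc1C(N)=O)CC(C)(C)CC2=O`) gives 93 nM, compound 2 (`Cc1c2c(n3c1CCCN[C@@H](C)[C@H](C)Nc1cc-3ccc1C(N)=O)CC(C)(C)CC2=O`) gives 29 nM and compound 3 (`Cc1c2c(n3c1CCN(C)C[C@@H](C)[C@H](C)Nc1cc-3ccc1C(N)=O)CC(C)(C)CC2=O`) gives 27 nM. Compound 2 therefore stands within the scatter of compound 3, and both have lower numbers than compound 1.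

Compound 4 (`Cc1c2c(n3c1CCCN(C(=O)CO)[C@@H](C)[C@H](C)Nc1cc-3ccc1C(N)=O)CC(C)(C)CC2=O`) is compound 2 with (hydroxymethyl)carbonyl in place of hydrogen on an amine nitrogen in a ring. Among the measured compounds shown here, the only measured step is a 3.2-fold lower number from compound 1 to compound 2 (0.51 log units; beyond the scatter), which comes from methyl in place of hydrogen on a saturated ring carbon. It is modest, but it involves a different group at a different place. For the measured compounds named here, no measured step shows what happens when a group replaces the hydrogen on this nitrogen, so the size of the new step can only be roughly judged. The entering group is much larger than that methyl, and a modest rise in the number seems the more likely outcome, though no change beyond the scatter remains possible. The expected change is a 1.7-fold higher number from compound 2 to compound 4 (0.24 log units; within the scatter). For compound 4 the estimated value is 50 nM, with an expected range from 12 nM to 200 nM.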

Compound 4, half-maximal inhibitory concentration: 51 nM
Estimate against measurement, compound 4: 1.0-fold (0.01 log units) below; low and high end bracket the measured number.
By their numbers in this assay, from the lowest: compounds 3, 2, 4 and 1 (each within the scatter of the next, the first and the last beyond it).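

In this assay, among the compounds shown here, putting (hydroxymethyl)carbonyl on this amine nitrogen in a ring gives a 1.8-fold higher number from compound 2 to compound 4 (0.25 log units; within the scatter), the first measured step at this nitrogen. A group of 4 heavy atoms, with no ring, can therefore replace the hydrogen here with no change that stands clear of the scatter, and compound 4 keeps its activity in this assay with no hydrogen left on that nitrogen. No measurement shown here offers an explanation for this result.

A single entering group cannot show whether the carbonyl or the terminal hydroxyl contributes anything on its own, and an acetyl group, which lacks that hydroxyl, would be the direct comparison with compound 4. From the compounds shown here alone, how far the tolerance at this nitrogen extends also remains open, whether to a longer chain such as 3-hydroxypropanoyl, to a carbonyl group ending in an amine or a carboxylic acid, or to a plain ethyl group with no carbonyl at all.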